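Trifluoromethoxyphenyl swap on a pyrazolone amide series

The compounds below may be only part of what the source reports. "The series", "measured", "known", "first", "only" and "open" are said of these compounds alone.

Compound 1 `Cc1cc(=O)n(-c2ccccc2OC(F)(F)F)nc1C(=O)Nc1ccc(Oc2ncnc3[nH]ccc23)cc1`: 32000 nM
Compound 2 `Cc1cc(=O)n(-c2ccc(F)cc2)nc1C(=O)Nc1ccc(Oc2ncnc3[nH]ccc23)c(F)c1`: 24500 nM
Compound 3 `Cc1ccc(-n2nc(C(=O)Nc3ccc(Oc4ncnc5[nH]ccc45)c(F)c3)c(C)cc2=O)cc1`: 18900 nM

In a functional assay on MCF7 cells (Homo sapiens) for cytotoxicity, read by MTT assay, with a stated time of 72 h (a lower number here means a stronger inhibitor, a higher number a weaker inhibitor), compound 3 gives the lowest of the three numbers, but its nearest neighbour compound 2 sits only a 1.3-fold lower number from compound 2 to compound 3 (0.11 log units; within the scatter) away, and compound 1 is also within the scatter of it, so no order among the three can be claimed. Compound 4 `Cc1cc(=O)n(-c2ccccc2OC(F)(F)F)nc1C(=O)Nc1ccc(Oc2ncnc3[nH]ccc23)c(F)c1` is obtained from compound 3 by 2-(trifluoromethoxy)phenyl in place of 4-methylphenyl on an aromatic nitrogen. Among the compounds with values here, no measured step matches this change directly. Within the data shown here, the one measured step, from compound 2 to compound 3, covers a different place and is within the scatter. Compound 1, which carries the same 2-(trifluoromethoxy)phenyl as compound 4 but lacks the fluoro, gives a number within the scatter of compound 3 in this assay. The account therefore expects compound 4 to move by about a 1.5-fold higher number from compound 3 to compound 4 (0.17 log units; within the scatter), a shift not beyond the scatter. The estimate for compound 4 in this assay is 28000 nM, with a range from 12000 nM to 65000 nM.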

Compound 4, half-maximal inhibitory concentration: 11700 nM
For compound 4 the middle estimate is 2.4-fold (0.38 log units) above the measured one, outside the stated range (below it).
By their numbers in this assay, from the lowest: compounds 4, 3, 2 and 1 (each within the scatter of the next, the first and the last beyond it).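

In this assay, 2-(trifluoromethoxy)phenyl in place of 4-methylphenyl on the aromatic nitrogen gives a 1.6-fold lower number from compound 3 to compound 4 (0.21 log units; within the scatter) and so cannot be told apart from it. Within the data shown here, the same group in place of 4-fluorophenyl gives a 2.1-fold lower number from compound 2 to compound 4 (0.32 log units; beyond the scatter) as a modest result, the first step at this position to pass the scatter. Among these compounds, the fluoro on the aromatic carbon, a place no earlier step covered, gives a 2.7-fold lower number from compound 1 to compound 4 (0.44 log units; beyond the scatter) with 2-(trifluoromethoxy)phenyl held constant, so this change is also modest but beyond the scatter.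

Nothing available accounts for these steps. Still open, as far as these compounds go, is whether the fluoro step holds with 4-methylphenyl or 4-fluorophenyl on the nitrogen, and how an amine or a carboxylic acid on that phenyl ring would read in this assay.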